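Fluoropyridinyl sulfone core with an ether side chain

A few compounds are considered here, and "the series" means these few. Any claim that something is new, unique, unknown or untested is made for them only; others in the source may bear on it.

Among the compounds with values here, the two compounds measured so far, compound 1 `CCCCc1nc(=O)c(S(=O)(=O)c2ccc(-c3ccnc(NC(=O)C4CC4)c3)cc2)c(O)n1-c1c(OC)cccc1OC` and compound 2 `CCCCc1nc(=O)c(S(=O)(=O)c2ccc(-c3ccc(F)nc3)cc2)c(O)n1-c1c(OC)cccc1OC`, share a core that differs only in the group on the aromatic carbon. In an ADME assay on microsomes from liver (Homo sapiens) for metabolic stability, using NADPH, with a stated time of 10 min (on this read-out higher numbers stand for a more stable compound and lower numbers for a less stable compound), compound 1 gives 84%, while compound 2 gives 100%. The step of a number 16 percentage points higher from compound 1 to compound 2 (beyond the scatter) therefore sets compound 2 as the higher of the two numbers, with compound 1 the nearest.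

Compound 3 `COc1cccc(OC)c1-n1c(COC(C)C)nc(=O)c(S(=O)(=O)c2ccc(-c3ccc(F)nc3)cc2)c1O` keeps the fluoropyridinyl side of compound 2 unchanged and alters the butyl chain of the core instead: isopropoxy in place of propyl on a saturated chain carbon bound to an aromatic carbon. Within the data shown here, no measured pair bears on this position; the only step seen, from compound 1 to compound 2, concerns the group on the aromatic carbon and says nothing about the chain. Compound 2 already stands at the top of the read-out, so the expected step of a number 10 percentage points lower from compound 2 to compound 3 (within the scatter) is estimated to be small or none beyond the scatter, with more room to move downward than upward. On this basis compound 3 is expected to give about 90% in this assay, within a range from 70% to 100%.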

Compound 3, percent of the compound remaining: 84%
Compound 3: the middle estimate sits 6 percentage points above what was measured, and the stated range covers the measured number.
By their numbers in this assay, from the lowest: compounds 1 and 3 (each within the scatter of the next); then compound 2.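

In this assay, the chain of the shared core turns out to matter: with the 6-fluoropyridin-3-yl group held fixed, isopropoxy in place of propyl on a saturated chain carbon bound to an aromatic carbon gives a number 16 percentage points lower from compound 2 to compound 3 (beyond the scatter). Within the data shown here, the earlier step concerned only the group on the aromatic carbon, so this pair is the first to show that the read-out also responds to a change in the chain, here from butyl to isopropoxymethyl. A single pair cannot separate the contribution of the entering oxygen from that of the branching, and nothing available accounts for the step.

The compounds shown leave open whether an unbranched ethoxymethyl chain, a longer alkyl chain or an amine in this place would stay close to compound 2 or fall nearer to compound 3. From the compounds shown here alone, it also remains open whether the change from butyl to isopropoxymethyl would produce a step of similar size with the 2-((cyclopropylcarbonyl)amino)pyridin-4-yl group of compound 1 on the aromatic carbon.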